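A few compounds are considered here, and "the series" means these few. Any claim that something is new, unique, unknown or untested is made for them only; others in the source may bear on it.

Working notes on the series. Compound 1 `C=C1CC[C@H]2C(C)(C)CCC[C@]2(C)[C@H]1C[C@@H](O)C1=CCOC1=O` and compound 2 `C=C1CC[C@H]2C(C)(C)CCC[C@]2(C)[C@H]1C/C=C1\C=COC1=O` share one core and differ in a single group. In a functional assay on RAW264.7 cells (Mus musculus) for inhibition, read by ELISA, with stated times of 1 h and 18 h, tested at 5 uM (on this read-out lower numbers stand for a stronger effect and higher numbers for a weaker effect at the one concentration tested), compound 1 gives 75.6%, and in this assay compound 2 gives 85.9%, the highest of the two numbers, with compound 1 lower by a gap beyond the usual scatter; on this read-out compound 2 is thus the weaker of the pair. Compound 3 `C=C1CC[C@H]2C(C)(C)CCC[C@]2(C)[C@H]1CC=O` is the next point. Relative to compound 2 the change is a group of 2 heavy atoms (1 carbon, 1 oxygen; no ring) in place of a group of 7 heavy atoms (5 carbon, 2 oxygen; one five-membered non-aromatic ring with 1 hetero atom), on a saturated chain carbon bound to a saturated ring carbon. Within the data shown here, no measured step of this kind exists, so the size of the step in this assay is open; the expectation is a shift toward higher numbers, that is a weaker effect, or none beyond the scatter, given that compound 2 already stands at 85.9%. Compound 3 is therefore estimated at 92% in this assay, within 78% to 104%. That estimate means an expected step of a number 6.1 percentage points higher from compound 2 to compound 3 (within the scatter).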

Compound 3, a percentage reported as activity, at one concentration (the size of the read-out at that concentration, not a potency): 93%
Estimate against measurement, compound 3: 1 percentage points below; the range from low to high includes it.
By their numbers in this assay, from the lowest: compound 1; then compounds 2 and 3 (each within the scatter of the next).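

In this assay, replacing the five-membered ring group with formyl, on a saturated chain carbon bound to a saturated ring carbon, gives a number 7.1 percentage points higher from compound 2 to compound 3 (within the scatter). Among these compounds, this is the first measured step at this place, and it shows that the two groups cannot be told apart in this assay, even though formyl has far fewer heavy atoms and no ring. The read-out therefore gives no sign that the full ring group of compound 2 is needed to keep the number seen there, and no other data on the series bear on this result.

From the compounds shown here alone, it remains open whether a carboxylic acid, an amine or a longer chain in place of the formyl would move the number beyond the scatter in either direction. With a single concentration shown, the potency of these compounds also remains open.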